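Moving the chloro substituent on the benzamide aryl

This account rests on a few compounds, and the source may have more. Where it says the series, first, only, none or still open, it means among the compounds named here.

Compound 1 `COc1cccc(C(=O)NCc2ccc(CNS(=O)(=O)c3ccc(C)cc3)cc2)c1` is the anchor of this short series. In an assay on MDA-MB-231 cells for binding affinity to C-X-C chemokine receptor type 4 (Homo sapiens), read by immunofluorescence and microscopy, with stated times of 10 min and 30 min (a higher number here means that more compound is needed for the effect, a lower number that less compound is needed), compound 1 gives 10 nM. Compound 2 `Cc1ccc(S(=O)(=O)NCc2ccc(CNC(=O)c3ccccc3Cl)cc2)cc1` carries a different aryl group on the carbonyl carbon, and in this assay compound 2 gives 10 nM. The one measured step, no change at the digits printed from compound 1 to compound 2 (within the scatter), shows that swapping the aryl group on the carbonyl carbon left the read-out unchanged within the scatter, so compound 2 stands level with compound 1 at the digits shown.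

Compound 3 `Cc1ccc(S(=O)(=O)NCc2ccc(CNC(=O)c3cccc(Cl)c3)cc2)cc1` is not yet measured. Its difference from compound 2 is 3-chlorophenyl in place of 2-chlorophenyl on a carbonyl carbon. Among the compounds with values here, the only relevant precedent is the step from compound 1 to compound 2, which also altered the aryl on the carbonyl carbon and produced no change. On that basis no step beyond the scatter is expected in this assay, and the expected step is no change at the digits printed from compound 2 to compound 3 (within the scatter). Compound 3 is therefore estimated at 10 nM, with a range from 4 nM to 25 nM.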

Compound 3, effective concentration (reported as EC, without a stated level of effect): 100 nM
Compound 3: the middle estimate sits 10-fold (1.00 log units) below what was measured; measured number above the stated range.
By their numbers in this assay, from the lowest: compounds 1 and 2 (each within the scatter of the next); then compound 3.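

In this assay the placement of the chloro group on the aryl at the carbonyl carbon counts, not merely its presence: with the same atoms joined differently, 3-chlorophenyl in place of 2-chlorophenyl brings a 10-fold higher number from compound 2 to compound 3 (1.00 log units; beyond the scatter) in this series. Chloro in place of methoxy on an aromatic carbon brings a 10-fold higher number from compound 1 to compound 3 (1.00 log units; beyond the scatter) as well, so 3-chlorophenyl and 3-methoxyphenyl are not interchangeable here, although 2-chlorophenyl and 3-methoxyphenyl read level. Nothing available explains either step.

Open, on these data alone, is how a fluoro, a nitrile or a carboxylic acid on this aryl would read in this assay and whether any of them would follow the same dependence on placement. Also open, as far as these compounds go, is whether 2-methoxyphenyl would read level with 2-chlorophenyl, which would show if the placement effect extends beyond chloro.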